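Small change to the strongest compound's ester chain

The source may report more compounds than this note shows. Statements on the series, on what has been measured and on what is new or still open speak of the compounds shown alone.

Compound 1 `COC(=O)c1cc(N2C(=O)C3=C(CCCC3)C2=O)ccc1Cl`: 2000 nM
Compound 2 `COC(=O)c1cc(N2C(=O)C3=C(CCCC3)C2=O)c(F)cc1Cl`: 110 nM
Compound 3 `CCCOC(=O)c1cc(N2C(=O)C3=C(CCCC3)C2=O)ccc1Cl`: 1860 nM

These values come from a functional assay on the whole organism with Scenedesmus acutus as the target; a higher number here means a weaker inhibitor, a lower number a stronger inhibitor. Compound 2 has the lowest number of the three, which makes it the strongest inhibitor so far. Compound 4 `CC(C)OC(=O)c1cc(N2C(=O)C3=C(CCCC3)C2=O)c(F)cc1Cl` differs from it by isopropyl in place of methyl on an oxygen next to a carbonyl group. The closest evidence is a 1.1-fold lower number from compound 1 to compound 3 (0.03 log units; within the scatter), a change on the same chain that stayed within the scatter. Among the compounds with values here, that step was seen without the fluoro group, and no measured compound carries isopropyl. The other step, an 18-fold lower number from compound 1 to compound 2 (1.26 log units; beyond the scatter), concerns the fluoro group, which compound 4 keeps. No change beyond the scatter is therefore expected in this assay, and the estimated step is a 1.1-fold higher number from compound 2 to compound 4 (0.04 log units; within the scatter). The expected value for compound 4 is 120 nM, with an estimated range of 50 nM to 300 nM.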

Compound 4, half-maximal inhibitory concentration: 57.5 nM
Estimate against measurement, compound 4: 2.1-fold (0.32 log units) above; low and high end bracket the measured number.
By their numbers in this assay, from the lowest: compounds 4 and 2 (each within the scatter of the next); then compounds 3 and 1 (each within the scatter of the next).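

Putting isopropyl in place of methyl on an oxygen next to a carbonyl group gives a 1.9-fold lower number from compound 2 to compound 4 (0.28 log units; within the scatter) in this assay. The earlier change on this chain was seen without the fluoro group, whereas this one shows that the chain can also be changed with the fluoro group kept and the numbers stay within the scatter of each other. No measured data bear on why this is so.

From the compounds shown here alone, a longer chain such as butyl, or a carboxylic acid in place of the ester, remains open. So does how isopropyl behaves without the fluoro group.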